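The source may hold more compounds than are shown below. What is called first, only, known or untested is meant among the compounds shown, and "the series" means these compounds.

In an assay on isolated protein for inhibition of thyroid hormone receptor beta (Homo sapiens), read by fluorescence, with a stated time of 30 min (on this read-out higher numbers stand for weaker inhibition and lower numbers for stronger inhibition), compound 1 `CCCN(CC1CCOC1)C(=O)c1cc(C)c2oc(NCc3cccc(Cl)c3)nc2c1` gives 35 nM. Compound 2 `CCCN(CC1CCOC1)C(=O)c1cc(OC)c2oc(NCc3cccc(Cl)c3)nc2c1` differs from it only by a methoxy in place of methyl on an aromatic carbon, and in this assay compound 2 gives 12 nM. That single step, a 2.9-fold lower number from compound 1 to compound 2 (0.46 log units; beyond the scatter), is a modest gain in inhibition. Within the data shown here, compound 2 therefore holds the lower of the two numbers measured so far, with compound 1 as its only neighbour.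

Compound 3 `COc1cc(C(=O)N2CCCC2)cc2nc(NCc3cccc(Cl)c3)oc12` keeps the methoxy-bearing core of compound 2 and changes the amide end: pyrrolidin-1-yl in place of ((oxolan-3-yl)methyl)(propyl)amino on a carbonyl carbon. Among the measured compounds shown here, no measured step touches this part of the molecule. For the measured compounds named here, the only known step, a 2.9-fold lower number from compound 1 to compound 2 (0.46 log units; beyond the scatter), concerns the aromatic substituent and offers no direct guide to the amide, so the size and direction of the coming change in this assay cannot be read from the data. The smaller ring that enters is expected to give a number of similar order, and compound 3 is estimated at 25 nM with a range from 7 nM to 90 nM. The expected step of a 2.1-fold higher number from compound 2 to compound 3 (0.32 log units; beyond the scatter) is thus small, within or only slightly beyond the scatter.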

Compound 3, half-maximal inhibitory concentration: 180 nM
For compound 3 the middle estimate is 7.2-fold (0.86 log units) below the measured one; measured number outside the range, above it.
By their numbers in this assay, from the lowest: compound 2; then compound 1; then compound 3.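

The amide end, which the earlier pair left untouched, has a strong effect in this assay: pyrrolidin-1-yl in place of ((oxolan-3-yl)methyl)(propyl)amino on the carbonyl carbon gives a 15-fold higher number from compound 2 to compound 3 (1.18 log units; beyond the scatter), a large loss of inhibition and a bigger step than the earlier change on the aromatic carbon, a 2.9-fold lower number from compound 1 to compound 2 (0.46 log units; beyond the scatter). This swap alters several things at once: the group that leaves has 10 heavy atoms and 1 hydrogen-bond acceptor, the group that enters has 5 heavy atoms and 0 hydrogen-bond acceptors, and each carries one five-membered non-aromatic ring. No independent data are available here to explain the loss.

The compounds shown leave open which part of the group that leaves accounts for the difference, as none of them separates the propyl chain from the oxolan-3-ylmethyl part. Going by these compounds, a propylamino or piperidin-1-yl group on the same carbonyl carbon would help to narrow this down, and it also remains open whether methoxy in place of methyl gives a similar step when pyrrolidin-1-yl sits on the carbonyl carbon.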